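Aryloxy N-substituents on the shared core: next step

The source may hold more compounds than are shown below. What is called first, only, known or untested is meant among the compounds shown, and "the series" means these compounds.

Measured compounds in an assay on HEK293 cells for inhibition of N-acylethanolamine-hydrolyzing acid amidase (Homo sapiens), read by fluorescence, with stated times of 10 min and 50 min; a lower number here means a stronger inhibitor, a higher number a weaker inhibitor:
- compound 1, `CCCCCON1C(=O)[C@@H](NC(=O)OCCCCC2CCCCC2)[C@@H]1C`: 387 nM
- compound 2, `COC(=O)c1ccc(ON2C(=O)[C@@H](NC(=O)OCCCCC3CCCCC3)[C@@H]2C)cc1`: 17 nM
- compound 3, `C[C@H]1[C@H](NC(=O)OCCCCC2CCCCC2)C(=O)N1Oc1ccc(Oc2ccccc2)cc1`: 48 nM

Compound 3 stands second of the three numbers; it sits a 2.8-fold higher number from compound 2 to compound 3 (0.45 log units; beyond the scatter) and, against compound 1, shows the lower of the two numbers, the two values lying beyond the scatter of each other. Two steps have been seen on this oxygen. The first, a 23-fold lower number from compound 1 to compound 2 (1.36 log units; beyond the scatter), is large and swaps an alkyl chain for an aryl ring; the second, a 2.8-fold higher number from compound 2 to compound 3 (0.45 log units; beyond the scatter), is modest and changes only the group on that ring.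

Compound 4, `C[C@H]1[C@H](NC(=O)OCCCCC2CCCCC2)C(=O)N1Oc1ccc(S(C)(=O)=O)cc1`, is to be measured. It differs from compound 3 in one place: methylsulfonyl in place of phenoxy on an aromatic carbon. Only the modest step bears on it, since the aryl ring is kept and only its substituent changes. A step of similar, modest size is therefore expected in this assay, with the number moving toward that of compound 2 rather than away from it; a move beyond the scatter is expected but not a large one.

Compound 4 is estimated at 25 nM, range 10 nM to 70 nM, which would mean a step of a 1.9-fold lower number from compound 3 to compound 4 (0.28 log units; within the scatter).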

Compound 4, half-maximal inhibitory concentration: 6 nM
Compound 4: the middle estimate sits 4.2-fold (0.62 log units) above what was measured; the measured number lies below the stated range.
By their numbers in this assay, from the lowest: compound 4; then compound 2; then compound 3; then compound 1.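

Notes on the substituent on the aryl ring: in this assay the change from phenoxy to methylsulfonyl gives an 8.0-fold lower number from compound 3 to compound 4 (0.90 log units; beyond the scatter) and shows that this place can still shift the number well after the aryl ring is in place. Methylsulfonyl, which carries no ring and has fewer heavy atoms than phenoxy, also improves on methoxycarbonyl with a 2.8-fold lower number from compound 2 to compound 4 (0.45 log units; beyond the scatter) and extends the gain over the pentyl compound to a 65-fold lower number from compound 1 to compound 4 (1.81 log units; beyond the scatter), leaving compound 4 with the lowest number of the four. No measurement is available to explain why methylsulfonyl ranks ahead of the other two groups.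

Still open, going by these compounds, is how a nitrile, a primary sulfonamide or a carboxylic acid at this same place would rank against methylsulfonyl. Also open, on these data alone, is where the aryl ring with no substituent at all would fall in this order.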